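Replacing pyridin-4-yl with 2-methoxyphenyl on an amide-type nitrogen

The source may hold more compounds than are shown below. What is called first, only, known or untested is meant among the compounds shown, and "the series" means these compounds.

Of the compounds shown here, three have so far been read in a functional assay on HCT-116 cells (Homo sapiens) for inhibition, read by colorimetric assay, with a stated time of 3 days; on this read-out lower numbers stand for stronger inhibition and higher numbers for weaker inhibition. Compound 1 `NC(=O)C(=O)NCCCCCCCC(=O)Nc1ccccc1` returned only a limit of the assay, > 100000 nM. Compound 3 `O=C(CCCCCCNC(=O)C(O)C(F)(F)F)Nc1nccs1` likewise returned only a limit, > 40000 nM. Among the compounds with values here, compound 2 `O=C(CCCCCCNC(=O)C(O)(O)C(F)(F)F)Nc1ccncc1` stands alone as the one compound with an actual number, 6670 nM, so it is the only numerical anchor.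

The next compound to be read is compound 4 `COc1ccccc1NC(=O)CCCCCCNC(=O)C(O)(O)C(F)(F)F`, which differs from compound 2 at a single place: 2-methoxyphenyl in place of pyridin-4-yl on an amide-type nitrogen. In plain terms, 2-methoxyphenyl takes the place of pyridin-4-yl on an amide-type nitrogen, and the rest of the structure stays the same. Within the data shown here, no pair of measured compounds differs in only one place, so the data give no direct measure of how large such a change might be. For that reason, no step beyond the usual scatter, in either direction, is expected in this assay, and the expectation stays anchored on compound 2 at 6670 nM. The estimated step is a 1.2-fold higher number from compound 2 to compound 4 (0.08 log units; within the scatter). For compound 4 the estimated value is 8000 nM, with an expected range from 2500 nM to 30000 nM.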

Compound 4, half-maximal inhibitory concentration: 10100 nM
Compound 4: middle estimate off by 1.3-fold (0.10 log units), on the low side; measured number inside the range.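

In this assay, within the data shown here, this is the first pair that differs in one place, and the exchange on the amide-type nitrogen gives a 1.5-fold higher number from compound 2 to compound 4 (0.18 log units; within the scatter). At this place, then, pyridin-4-yl and 2-methoxyphenyl cannot be told apart, and the ring nitrogen of pyridin-4-yl is not required for a measurable number, since a six-membered aromatic ring of carbon only also gives one when the rest of the structure is kept. Nothing shown here bears on why the two groups read alike.

Among these compounds, compound 1 and compound 3 returned only limits of the assay and differ from compound 2 in more than one place, so they add no further step at this position. The compounds shown leave open how a cyclohexyl group, an aminophenyl group or a carboxyphenyl group would read on this nitrogen, and whether a longer chain would change the picture when the rest of the structure of compound 4 is kept.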